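Carboxymethyl on the nitrogen chain: compound 2 to compound 3

The compounds below may be only part of what the source reports. "The series", "measured", "known", "first", "only" and "open" are said of these compounds alone.

In a functional assay on HT-29 cells (Homo sapiens) for inhibition, with a stated time of 72 h (a higher number here means a weaker inhibitor, a lower number a stronger inhibitor), compound 1 (`CCn1ccc2cc(C(=O)c3cc(OC)c(OC)c(OC)c3)ccc21`) gives 32 nM and compound 2 (`COc1cc(C(=O)c2ccc3c(ccn3CO)c2)cc(OC)c1OC`) gives 34 nM, so these two values lie within the scatter of each other. Compound 3 (`COc1cc(C(=O)c2ccc3c(ccn3CCC(=O)O)c2)cc(OC)c1OC`) has carboxymethyl in place of hydroxy on a saturated chain carbon bound to an aromatic nitrogen. Among the compounds with values here, the only measured step that bears on this is a 1.1-fold higher number from compound 1 to compound 2 (0.03 log units; within the scatter). That step exchanges far fewer atoms, so it is a weak guide, and a weaker inhibitor is expected here, with wide uncertainty. The expected change is a 5.9-fold higher number from compound 2 to compound 3 (0.77 log units; beyond the scatter). For compound 3 the estimate is 200 nM, with an expected range of 40 nM to 1500 nM.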

Compound 3, half-maximal inhibitory concentration: > 10000 nM
Compound 3: no number, only a limit (the forecaster's own chance of this, stated with the estimate: 10%); at least 50-fold (1.69 log units) between middle value and limit.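

The swap of hydroxy for methyl on this chain stayed within the scatter, so the position looked tolerant, yet carboxymethyl in place of hydroxy gives an at least 290-fold higher number from compound 2 to compound 3 (2.46 log units; beyond the scatter) in this assay. Compound 3 gives > 10000 nM, a limit of the assay and not a number. Carboxy in place of hydrogen reads the same way, with an at least 310-fold higher number from compound 1 to compound 3 (2.49 log units; beyond the scatter), so the tolerance does not reach this chain end.

Going by these compounds, whether the carboxy group or the added chain length carries the loss stays open. A methyl ester, a primary amide or an amine on the same chain would separate the two.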